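This account rests on a few compounds, and the source may have more. Where it says the series, first, only, none or still open, it means among the compounds named here.

In an ADME assay on HEK293 cells (Homo sapiens) for cytotoxicity, read by MTT assay, with a stated time of 48 h (on this read-out higher numbers stand for lower toxicity in this test and lower numbers for higher toxicity in this test), compound 1 `CCc1ccc(S(=O)(=O)NCCC[C@H]2C(=O)N(c3ccc(C)cc3)[C@@H]2c2ccc([N+](=O)[O-])cc2)cc1` gives > 100000 nM and this is a limit, not a number. Compound 2 `CCc1ccc(S(=O)(=O)NCCC[C@H]2C(=O)N(c3ccc(C)cc3)[C@@H]2c2ccc(NS(C)(=O)=O)cc2)cc1` gives > 100000 nM and this too is a limit. Compound 3 `CCc1ccc(S(=O)(=O)NCCC[C@H]2C(=O)N(c3ccc(C)cc3)[C@@H]2c2ccc(NS(=O)(=O)c3ccc(C)cc3)cc2)cc1` differs from compound 1 by ((4-methylphenyl)sulfonyl)amino in place of nitro on an aromatic carbon and so carries ((4-methylphenyl)sulfonyl)amino in place of nitro. The nearest measured change, a step that the two limits leave unreadable from compound 1 to compound 2 with compound 2 at its end, has no readable size, and the limit of > 100000 nM in this assay, at which 2 of the 2 values shown sit, describes all the evidence. No clear step is therefore expected in this assay in either direction. The expected step is a number no higher from compound 1 to compound 3 (the limit leaves the size open) on this estimate. Compound 3 is estimated at 100000 nM with an expected range from 40000 nM to 200000 nM in this test.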

Compound 3, concentration lethal to 50% of the cells in the HEK293 assay: 42900 nM
Beside the measured number, compound 3's estimate is 2.3-fold (0.37 log units) above it; the range from low to high includes it.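

In the HEK293 assay, compound 1 gives > 100000 nM, and this is a limit, not a number. In the HEK293 assay, compound 2 gives > 100000 nM, and this too is a limit. Among the compounds shown here, in the HEK293 assay, compound 3 gives 42900 nM and with it the first readable steps at this aromatic carbon, where the step between compound 1 and compound 2 cannot be read: an at least 2.3-fold lower number from compound 1 to compound 3 (0.36 log units; beyond the scatter) for ((4-methylphenyl)sulfonyl)amino in place of nitro. The comparison with the methanesulfonamido compound, an at least 2.3-fold lower number from compound 2 to compound 3 (0.36 log units; beyond the scatter), ties this shift towards higher toxicity in this test to 4-methylphenyl in place of methyl on a sulfonyl sulfur. In a physicochemical assay for lipophilicity, read by HPLC, measured as octanol-water partition (a higher number here means a more lipophilic compound, a lower number a more polar compound), compound 1 gives >= 4.4, and this is a limit, not a number. In the physicochemical assay, compound 3 gives 3.4, and the change from nitro also lowers the number, with a number at least 1.00 log units lower from compound 1 to compound 3 (beyond the scatter).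

From the compounds shown here alone, whether a plain phenyl on the sulfonyl sulfur, or an amine on the aromatic carbon, would also give a readable number in the HEK293 assay stays open.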